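This account rests on a few compounds, and the source may have more. Where it says the series, first, only, none or still open, it means among the compounds named here.

Compound 1 `Cc1ccc(C2=NN(C(=S)Nc3ccccc3)C(c3ccc4c(c3)OCCO4)C2)cc1`: 19500 nM
Compound 2 `S=C(Nc1ccccc1)N1N=C(c2ccccc2Br)CC1c1ccc2c(c1)OCCO2`: > 200000 nM
Compound 3 `S=C(Nc1ccccc1)N1N=C(c2ccc(OCc3ccccc3)cc2)CC1c1ccc2c(c1)OCCO2`: 860 nM

In a functional assay on HT-29 cells (Homo sapiens) for antiproliferative activity, read by MTT assay, with a stated time of 48 h (on this read-out lower numbers stand for stronger inhibition of growth and higher numbers for weaker inhibition of growth), compound 2 gives only a limit of the measurement, > 200000 nM. It stands at the limit of > 200000 nM in this assay, at which 1 of the 3 values shown sits, the weakest position among the three values shown. Compound 4 `S=C(Nc1ccccc1)N1N=C(c2cccs2)CC1c1ccc2c(c1)OCCO2` differs from compound 2 in one place: thiophen-2-yl in place of 2-bromophenyl on a carbon with a double bond to nitrogen. For the measured compounds named here, two measured steps bear on this change. The step of an at least 10-fold higher number from compound 1 to compound 2 (1.01 log units; beyond the scatter) shows that bringing in 2-bromophenyl on that carbon pushed the number up strongly, and the step of a 23-fold lower number from compound 1 to compound 3 (1.36 log units; beyond the scatter) shows how far a change on the same aryl group can move the number the other way. Taking 2-bromophenyl out again is therefore expected to bring the number down, by about an at least 8.0-fold lower number from compound 2 to compound 4 (0.90 log units; beyond the scatter). Compound 4 is expected to give roughly 25000 nM, within the range 5000 nM to 150000 nM.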

Compound 4, concentration for 50% growth inhibition: 188000 nM
For compound 4 the middle estimate is 7.5-fold (0.88 log units) below the measured one; the measured number lies above the stated range.
By their numbers in this assay, from the lowest: compound 3; then compound 1; then compound 4. At a limit, above all of these: compound 2.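

The step of an at least 1.0-fold lower number from compound 2 to compound 4 (0.02 log units; that floor lies within the scatter) rests on a limit and its floor lies within the scatter, so it sets no order between these two. The step of a 9.6-fold higher number from compound 1 to compound 4 (0.98 log units; beyond the scatter) is the readable one: thiophen-2-yl on this carbon gives much weaker growth inhibition than 4-methylphenyl. Weak inhibition at this position is therefore not confined to 2-bromophenyl, and compound 3, with its benzyloxy group, remains the one that goes the other way.

Going by these compounds, it remains open whether an amine or a carboxylic acid in place of that benzyloxy group would keep the stronger inhibition.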